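Five-membered ring swap from compound 1 to compound 4

The source may hold more compounds than are shown below. What is called first, only, known or untested is meant among the compounds shown, and "the series" means these compounds.

Working notes on the series. Compound 1 `O=C(O)c1cc(C2N=NN=N2)ccc1O` carries a five-membered non-aromatic ring with four hetero atoms on an aromatic carbon of the shared core. In a functional assay on the whole organism for inhibition, with Rattus norvegicus as the target, read by paw edema (a higher number here means that more compound is needed for the effect, a lower number that less compound is needed), compound 1 gives 110 mg/kg, the highest of the two numbers in hand. Compound 3 `CCCCOC(=O)Oc1ccc(-n2cccc2)cc1C(=O)O` gives 52 mg/kg in this assay, a step beyond the usual scatter. For compound 2 `O=C(O)c1cc(-c2ccncn2)ccc1O` this assay reports only a limit, > 200 mg/kg, so compound 2 sits at the limit of > 200 mg/kg in this assay, at which 1 of the 3 values shown sits, and no number is known for it.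

Compound 4 `O=C(O)c1cc(-n2nccn2)ccc1O` is not yet measured. It differs from compound 1 by a group of 5 heavy atoms (2 carbon, 3 nitrogen; one five-membered aromatic ring with 3 hetero atoms) in place of a group of 5 heavy atoms (1 carbon, 4 nitrogen; one five-membered non-aromatic ring with 4 hetero atoms), on an aromatic carbon. Within the data shown here, no step between two measured compounds that differ in one place is available, so nothing in hand tells how large a change in this assay such a swap brings. The step from compound 1 to compound 4 is therefore expected to stay within the scatter, in either direction, as a 1.1-fold higher number from compound 1 to compound 4 (0.04 log units; within the scatter). Compound 4 is thus estimated at 120 mg/kg in this assay, with a range from 50 mg/kg to 250 mg/kg, and a limit rather than a number remains possible.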

Compound 4, dose for half-maximal effect: 150 mg/kg
For compound 4 the middle estimate is 1.3-fold (0.10 log units) below the measured one; low and high end bracket the measured number.
By their numbers in this assay, from the lowest: compound 3; then compounds 1 and 4 (each within the scatter of the next). At a limit, above all of these: compound 2.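

The swap of the five-membered non-aromatic ring for 2H-1,2,3-triazol-2-yl, on the aromatic carbon para to a hydroxy group and meta to a carboxy group, gives in this assay a 1.4-fold higher number from compound 1 to compound 4 (0.13 log units; within the scatter). Among these compounds, this is the first step that can be read at this position, and it shows that this exchange of one five-membered ring for another leaves the number indistinguishable from that of the starting compound. For compound 2, with a different ring at this position, the entry remains a limit and not a number: the limit of > 200 mg/kg in this assay, at which 1 of the 4 values shown sits.

On these data alone, whether an amine or a longer alkyl chain on this carbon would move the number beyond the scatter stays open. Compound 3 differs from compound 1 in more than one place, so its value cannot be assigned to any single change.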